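The compounds below may be only part of what the source reports. "The series", "measured", "known", "first", "only" and "open" are said of these compounds alone.

Working notes on the series. Compound 1 `Cc1ccc(S(=O)(=O)N/C(=N\O)Nc2ccc(Cl)cc2)cc1` gives 46 ug/mL in a functional assay on KB cells (Homo sapiens) for cytotoxicity; on this read-out higher numbers stand for weaker inhibition and lower numbers for stronger inhibition. Compound 2 `O=[N+]([O-])c1ccc(Oc2c(Cl)cc(S(=O)(=O)N/C(=N\O)Nc3ccc(Cl)cc3)cc2Cl)cc1` gives 12 ug/mL in this assay, and compound 3 `O=[N+]([O-])c1ccc(Oc2c(Cl)cc(S(=O)(=O)N/C(=N\O)Nc3ccc(Cl)cc3)cc2Cl)c(Cl)c1` gives 7 ug/mL. The difference between the core of compound 1 and the core of compound 2 is not broken down here; the values simply show compound 1 with the highest number of the three, beyond the scatter from both others.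

Compound 3 differs from compound 2 by chloro in place of hydrogen on an aromatic carbon. The step was a 1.7-fold lower number from compound 2 to compound 3 (0.23 log units; within the scatter). Compound 4 `Cc1ccc(S(=O)(=O)N/C(=N\O)Nc2ccc(Cl)c(Cl)c2)cc1`, not yet measured, differs from compound 1 by chloro in place of hydrogen on an aromatic carbon. This is the same kind of change, but not the same: in compound 3 the entering chloro sits ortho to a large group and meta to a nitro group, whereas in compound 4 it sits ortho to a chloro group and meta to a large group.

Within the data shown here, for compound 4 in this assay the expected step is a 1.5-fold lower number from compound 1 to compound 4 (0.19 log units; within the scatter), a change of about the size seen for compound 3, resting on the single earlier step of a 1.7-fold lower number from compound 2 to compound 3 (0.23 log units; within the scatter) and on the value of compound 1, 46 ug/mL. The estimate for compound 4 is 30 ug/mL, expected between 12 ug/mL and 75 ug/mL.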

Compound 4, half-maximal inhibitory concentration: 8 ug/mL
The estimate for compound 4 lay 3.8-fold (0.57 log units) above the measured number; the whole stated range lies above it.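

In this assay chloro in place of hydrogen gives a 5.8-fold lower number from compound 1 to compound 4 (0.76 log units; beyond the scatter), so the change does not carry from one core to the other at a single size: the same change on two cores in this assay, a 1.7-fold lower number (0.23 log units; within the scatter) from compound 2 to compound 3 and a 5.8-fold lower number (0.76 log units; beyond the scatter) from compound 1 to compound 4, 3.4-fold (0.53 log units) apart, beyond the scatter of two such steps

Among these compounds, both steps run towards a lower number, but only the step on the core of compound 1 lies beyond the scatter. The pair shows that the size of this step cannot simply be transferred within the series, yet it does not show what sets the size, since the core and the surroundings of the entering chloro differ together, and two steps make no rule.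

Still open, as far as these compounds go, is how a fluoro, bromo, methyl or methoxy group would read in the place the chloro takes in compound 4, ortho to a chloro group, on the core of compound 1. Also open, from the compounds shown here alone, is how a second chloro in that same place would read on the core of compound 2, which would separate the core from the place.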